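A Pyrimidinyl Replaces a Phenylethyl at the Ring Nitrogen

A few compounds are considered here, and "the series" means these few. Any claim that something is new, unique, unknown or untested is made for them only; others in the source may bear on it.

Three compounds sharing one core were tested in an ADME assay on RAW264.7 cells (Mus musculus) for cytotoxicity, read by MTT assay, with a stated time of 72 h, tested at 50 uM; on this read-out lower numbers stand for less inhibition and higher numbers for more inhibition at the one concentration tested (going by the name of the read-out). Compound 1, `CC(=O)N1CCN(CC(=O)N2CCN(c3cc4c(cc3F)c(=O)c(C(=O)O)cn4C3CC3)CC2)CC1`, gives 16.2%. Compound 2, `Cc1cccc(N2CCN(CC(=O)N3CCN(c4cc5c(cc4F)c(=O)c(C(=O)O)cn5C4CC4)CC3)CC2)c1`, gives 16.2%. Compound 3, `CC(c1ccccc1)N1CCN(CC(=O)N2CCN(c3cc4c(cc3F)c(=O)c(C(=O)O)cn4C3CC3)CC2)CC1`, gives 16.9%. Compound 3 holds the highest of the three numbers, but the steps of a number 0.7 percentage points higher from compound 1 to compound 3 (within the scatter) and a number 0.7 percentage points higher from compound 2 to compound 3 (within the scatter) are both within the scatter, so no real difference among the three can be claimed.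

Compound 4, `O=C(O)c1cn(C2CC2)c2cc(N3CCN(C(=O)CN4CCN(c5ncccn5)CC4)CC3)c(F)cc2c1=O`, has not yet been measured. It differs from compound 3 in one place: pyrimidin-2-yl in place of 1-phenylethyl on an amine nitrogen in a ring. Going by the values given here, the steps that bear on this change are the earlier swaps at the same ring nitrogen, no change at the digits printed from compound 1 to compound 2 (within the scatter) and a number 0.7 percentage points higher from compound 1 to compound 3 (within the scatter), neither of which moved the number beyond the scatter. Replacing the 1-phenylethyl with pyrimidin-2-yl at that nitrogen is therefore expected to give a step of a number 0.4 percentage points lower from compound 3 to compound 4 (within the scatter), essentially none beyond the scatter. Compound 4 is estimated at 16.5%, within a range from 6% to 28%.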

Compound 4, a percentage reported as inhibition, at one concentration (the size of the read-out at that concentration, not a potency): 11%
The estimate for compound 4 lay 5.5 percentage points above the measured number; low and high end bracket the measured number.
By their numbers in this assay, from the lowest: compounds 4, 1, 2 and 3 (each within the scatter of the next).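

Among the groups shown at this ring nitrogen, only pyrimidin-2-yl has hetero atoms in its aromatic ring, and in this assay it gives the largest steps yet seen at this position: a number 5.9 percentage points lower from compound 3 to compound 4 (within the scatter), a number 5.2 percentage points lower from compound 2 to compound 4 (within the scatter) and a number 5.2 percentage points lower from compound 1 to compound 4 (within the scatter). Going by these compounds alone, all three steps remain within the scatter, so even this change of ring type separates no compound from the others, and acetyl, 3-methylphenyl, 1-phenylethyl and pyrimidin-2-yl cannot be told apart on this read-out. No supporting measurement bears on the size of these steps.

Going by these compounds, whether a group of another kind on this nitrogen, such as a carboxylic acid or an amine on a longer chain, would give a step beyond the scatter remains open. On these data alone, with one concentration tested, how these compounds compare at higher concentrations also remains open.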